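A few compounds are considered here, and "the series" means these few. Any claim that something is new, unique, unknown or untested is made for them only; others in the source may bear on it.

Compound 1 `Nc1ncnc2c1ncn2[C@@H]1O[C@H](CNC(=O)C[C@H](N)C(=O)O)[C@@H](O)[C@H]1O` and compound 2 `Nc1ncnc2c1ncn2[C@@H]1O[C@H](CNC(=O)CC[C@H](N)C(=O)O)[C@@H](O)[C@H]1O` share their core with compound 3 `Nc1ncnc2c1ncn2[C@@H]1O[C@H](CN(CC[C@H](N)C(=O)O)CC2CCC2)[C@@H](O)[C@H]1O`; in an assay for inhibition of tRNA (cytosine(38)-C(5))-methyltransferase (Homo sapiens), with a stated time of 5 min, tested at 100 uM (a lower number here means less inhibition, a higher number more inhibition at the concentration tested (going by the name of the read-out)), compound 1 gives no result reported and compound 2 gives no result reported, so neither of the first two offers a point of comparison. Among the measured compounds shown here, compound 3 is thus the only compound with a value: in this assay compound 3 gives 32%. For the measured compounds named here, that single figure can be read as moderate inhibition at the concentration tested, but it stands alone, and no step between two measured compounds is available to show how far a change of one group usually moves this read-out.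

Compound 4 `Nc1ncnc2c1ncn2[C@@H]1O[C@H](CN(CC[C@H](N)C(=O)O)Cc2ccccc2)[C@@H](O)[C@H]1O` is the next compound to be tested. It differs from compound 3 in one place: phenyl in place of cyclobutyl on a saturated chain carbon bound to an amine nitrogen. The rest of the molecule, including the amine-bearing chain and the core, is unchanged.

Going by the values given here, with no measured pair to lean on, there is no footing for predicting a large shift in either direction. The expected step from a number 4 percentage points higher from compound 3 to compound 4 (within the scatter) is therefore small, a slight rise that stays within the scatter of repeated measurements. For compound 4 the estimated value in this assay is 36%, with an expected range from 15% to 60%.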

Compound 4, a percentage reported as inhibition, at one concentration (the size of the read-out at that concentration, not a potency): 56.8%
For compound 4 the middle estimate is 20.8 percentage points below the measured one, within the range that was stated.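

In this assay, among the compounds shown here, placing phenyl in place of cyclobutyl on a saturated chain carbon bound to an amine nitrogen gives a number 24.8 percentage points higher from compound 3 to compound 4 (beyond the scatter) and provides the first readable step in this set, showing that the read-out responds to the group at this position. Neither group carries a hydrogen-bond donor, a hydrogen-bond acceptor or a net charge, but the change swaps a four-membered non-aromatic ring for a six-membered aromatic one, so ring size and aromatic character change together and this single step cannot separate them. No measurement shown here bears on why the number rose.

Cyclohexylmethyl, which keeps a six-membered ring without the aromatic one, would help to separate those two features, while phenethyl, with a longer chain, and a benzyl group carrying a methoxy group would show how much further this position can be varied. As far as these compounds go, compounds 1 and 2 have no number, so steps involving them cannot be read, and the effect of their amide link compared with the amine of compound 3 and compound 4 remains open.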